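The source may report more compounds than this note shows. Statements on the series, on what has been measured and on what is new or still open speak of the compounds shown alone.

In a functional assay on MT4 cells (Homo sapiens) for cytotoxicity (on this read-out higher numbers stand for lower toxicity in this test and lower numbers for higher toxicity in this test), compound 3 `Cc1c(O)nc(SCC(=O)c2ccc(F)cc2)nc1Cc1cccc2ccccc12` stands at a limit of the assay, >= 275000 nM, not at a number. Compound 1 `Cc1ccc(C(=O)CSc2nc(O)c(C)c(Cc3cccc4ccccc34)n2)cc1` likewise sits at a limit in this assay, >= 251000 nM. Compound 2 `CC(=O)CSc1nc(O)c(C)c(Cc2cccc3ccccc23)n1` is the only one of the three with a plain number, giving 85000 nM in this assay. The step to compound 4 `CCOC(=O)CSc1nc(O)c(C)c(Cc2cccc3ccccc23)n1` makes the change (ethoxy in place of 4-fluorophenyl on a carbonyl carbon). Among the measured compounds shown here, two measured steps touch the same carbonyl carbon: an at least 2.9-fold lower number from compound 1 to compound 2 (0.47 log units; beyond the scatter) and an at least 3.2-fold higher number from compound 2 to compound 3 (0.50 log units; beyond the scatter), so removing an aromatic ring from that carbon has gone with a lower number. For compound 4 a lower number than compound 3 is therefore expected, an at least 2.7-fold lower number from compound 3 to compound 4 (0.43 log units; beyond the scatter), and the estimate for compound 4 is 100000 nM, within 40000 nM to 275000 nM.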

Compound 4, half-maximal cytotoxic concentration: >= 287000 nM
Compound 4: a limit, no number; the forecaster's own chance of this, stated with the estimate: 30%; middle value at least 2.8-fold (0.45 log units) from the limit.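

In this assay, ethoxy on the carbonyl carbon, which carries no ring, goes with an at least 3.3-fold higher number from compound 2 to compound 4 (0.52 log units; beyond the scatter), so the lower number of compound 2 does not follow simply from the loss of an aromatic ring. Compound 4 stands at a limit, not a number: the limit of >= 287000 nM in this assay, at which 1 of the 4 values shown sits. The steps to compound 4 from compound 1 and from compound 3 cannot be read.

As far as these compounds go, only the methyl compound gives a plain number, so any order among the other three groups stays open. Also open, from the compounds shown here alone, is whether an amine, a carboxylic acid or a longer alkoxy chain on this carbonyl carbon would give the high or the low number.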